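The compounds below may be only part of what the source reports. "The series", "measured", "known", "first", "only" and "open" are said of these compounds alone.

For the measured compounds named here, in a functional assay on SJSA-1 cells (Homo sapiens) for inhibition, read by MTT assay (a higher number here means a weaker inhibitor, a lower number a stronger inhibitor), compound 2 (`CC(C)(C)C[C@@H]1N[C@@H](C(=O)Nc2ccc(C(=O)O)cc2)[C@H](c2cccc(Cl)c2F)[C@@]1(C#N)c1ccc(Cl)cc1F`) gives 40 nM and holds the lower of the two numbers so far, while compound 1 (`CC(C)(C)C[C@@H]1N[C@@H](C(=O)Nc2ccn(CC(C)(C)O)n2)[C@H](c2cccc(Cl)c2F)[C@@]1(C#N)c1ccc(Cl)cc1F`) gives 1320 nM on the same core. Compound 3 (`COc1cc(NC(=O)[C@@H]2N[C@@H](CC(C)(C)C)[C@](C#N)(c3ccc(Cl)cc3F)[C@H]2c2cccc(Cl)c2F)ccc1C(=O)O`) differs from compound 2 in one place: methoxy in place of hydrogen on an aromatic carbon (methoxy in place of hydrogen on an aromatic carbon, ortho to a carboxy group and meta to a large group). Going by the values given here, the only measured step is a 33-fold lower number from compound 1 to compound 2 (1.52 log units; beyond the scatter) and it is large, but it exchanges the whole group on the amide-type nitrogen. Among the compounds with values here, it bears only loosely on a single added methoxy, and no measured pair carries that group. A step within the scatter is therefore expected in this assay with no firm direction. The expected move is a 1.3-fold lower number from compound 2 to compound 3 (0.12 log units; within the scatter) and no more. Compound 3 is estimated at 30 nM with an expected range of 12 nM to 80 nM in this read-out.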

Compound 3, half-maximal inhibitory concentration: 30 nM
Estimate against measurement, compound 3: no gap at the digits printed, within the range that was stated.
By their numbers in this assay, from the lowest: compounds 3 and 2 (each within the scatter of the next); then compound 1.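

In this assay, the change from 4-carboxyphenyl to 4-carboxy-3-methoxyphenyl gives a 1.3-fold lower number from compound 2 to compound 3 (0.12 log units; within the scatter), so this aromatic carbon, ortho to a carboxy group and meta to a large group, carries a methoxy with no step beyond the scatter. With that methoxy in place, the exchange of the whole group on the amide-type nitrogen still gives a large step, a 44-fold lower number from compound 1 to compound 3 (1.64 log units; beyond the scatter), so the methoxy does not remove the separation from compound 1. No measurement is available here to explain either step.

On these data alone, whether an ethoxy or an amine on this same aromatic carbon would also stay within the scatter of compound 2 remains open. Also open, as far as these compounds go, is how a carboxamide in place of the carboxy group would read in this assay, with or without the methoxy.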